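This account rests on a few compounds, and the source may have more. Where it says the series, first, only, none or still open, it means among the compounds named here.

Working notes on the series. Two compounds on the shared core have numbers in a functional assay on HT-29 cells (Homo sapiens) for antiproliferative activity; a lower number here means a stronger inhibitor, a higher number a weaker inhibitor. Compound 1 `COc1ccc(S(=O)(=O)N2CCc3cccc(Nc4ccc(O)cc4)c32)cc1` gives 511 nM in this assay, and compound 2 `COc1ccc(S(=O)(=O)N2CCc3cccc(Nc4ccc(F)cc4)c32)cc1` gives 588 nM. For the measured compounds named here, the only step between them, a 1.2-fold higher number from compound 1 to compound 2 (0.06 log units; within the scatter), is within the scatter. On the numbers shown, compound 2 stands highest of the two, with compound 1 nearest at a step within the scatter, so no order between the two can be claimed.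

Compound 3 `COc1ccc(S(=O)(=O)N2CCc3cccc(Nc4ccc(C(=O)O)cc4)c32)cc1` has not yet been measured in this assay. Its change from compound 2 is carboxy in place of fluoro on an aromatic carbon. Going by the values given here, no measured step exchanges fluoro for carboxy or for any group with a hydrogen-bond donor and acceptor at that position; the step from compound 1 to compound 2 only shows that hydroxy and fluoro on that aromatic carbon give numbers within the scatter of each other. The expectation for compound 3 therefore rests on little, and a step of a 2.0-fold higher number from compound 2 to compound 3 (0.31 log units; beyond the scatter) toward a weaker inhibitor is estimated, with wide uncertainty. Compound 3 is expected to give about 1200 nM in this assay, within a range from 400 nM to 4000 nM.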

Compound 3, half-maximal inhibitory concentration: 2380 nM
Beside the measured number, compound 3's estimate is 2.0-fold (0.30 log units) below it; the range from low to high includes it.
By their numbers in this assay, from the lowest: compounds 1 and 2 (each within the scatter of the next); then compound 3.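

In this assay this position, on an aromatic carbon para to a large group, now proves sensitive to what stands on it: the series shows a 4.0-fold higher number from compound 2 to compound 3 (0.61 log units; beyond the scatter) for carboxy in place of fluoro, and a 4.7-fold higher number from compound 1 to compound 3 (0.67 log units; beyond the scatter) for carboxy in place of hydroxy. For the compounds shown here, until now the only exchange at this carbon, hydroxy to fluoro, had stayed within the scatter, so the position could have seemed to tolerate any change; both new steps instead lie beyond the scatter and run toward a weaker inhibitor, whichever of the two earlier groups carboxy replaces. Nothing available explains why carboxy gives the weaker inhibitor here.

Carboxy differs from both earlier groups in more than one way, since it brings three heavy atoms and a double bond outside the aromatic ring, so the compounds shown do not say which of these features carries the step. From the compounds shown here alone, a methyl ester, a primary amide or an amine on the same aromatic carbon would help separate these features, and whether the step holds with other changes elsewhere on the shared core also stays open.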